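The compounds below may be only part of what the source reports. "The series", "measured", "known", "first", "only" and "open" are said of these compounds alone.

Measured so far in a functional assay on CCRF-CEM cells (Homo sapiens) for cytotoxicity, read by MTT assay, with a stated time of 72 h; on this read-out higher numbers stand for weaker inhibition of growth and lower numbers for stronger inhibition of growth:
compound 1 `C[Se]c1nc(N)c2ccccc2n1` gives 65100 nM;
compound 2 `[SeH]c1nc([SeH])c2ccccc2n1` gives 2990 nM;
compound 3 `COc1ccc(CNc2nc(SC)nc3ccccc23)cc1` gives 93700 nM.

Compound 2 carries the lowest number of the three. Compound 1 and compound 3 both sit at higher numbers, and both gaps lie beyond the scatter, so compound 2 is the strongest inhibitor of growth among the measured compounds. Going by the values given here, no two measured compounds differ in a single place, so no measured step is available in this assay .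

Compound 4 `Nc1nc([SeH])nc2ccccc12` is not yet measured. It differs from compound 2 thus: one nitrogen atom in place of one selenium atom, on an aromatic carbon. Among the measured compounds the only one bearing an amino group is compound 1, which gives 65100 nM, a number beyond the scatter above compound 2, though compound 1 also differs in its other substituent. On that basis the step upward is expected to lie beyond the scatter but to stay short of the gap between compound 2 and compound 1. Compound 4 is expected at 15000 nM, within a range of 4000 nM to 55000 nM. The step from compound 2 to compound 4 is estimated as a 5.0-fold higher number from compound 2 to compound 4 (0.70 log units; beyond the scatter) toward weaker inhibition of growth.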

Compound 4, concentration for 50% growth inhibition: 25700 nM
The estimate for compound 4 lay 1.7-fold (0.23 log units) below the measured number, within the range that was stated.
By their numbers in this assay, from the lowest: compound 2; then compound 4; then compounds 1 and 3 (each within the scatter of the next).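

Going by these compounds alone, compound 4 gives the first single-place reading at this position in this assay: with one nitrogen atom in place of one selenium atom, on an aromatic carbon, the step is an 8.6-fold higher number from compound 2 to compound 4 (0.93 log units; beyond the scatter), toward weaker inhibition of growth. The second step shows that the substituent on the remaining selenium also counts when the amino group is held fixed: hydrogen in place of methyl on a selenium gives a 2.5-fold lower number from compound 1 to compound 4 (0.40 log units; beyond the scatter), toward stronger inhibition of growth. No supporting data bear on why either change moves the number.

The compounds shown leave open whether the loss at this position is specific to amino or would also follow with a hydroxyl or a methylamino group there. They also leave open how an ethyl or longer chain on the selenium would compare with methyl and hydrogen.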